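Methoxy in Place of Methyl: Expecting Compound 4

A few compounds are considered here, and "the series" means these few. Any claim that something is new, unique, unknown or untested is made for them only; others in the source may bear on it.

Measured compounds:
compound 1 `O=C(Nc1ccc(I)cc1)N[C@H]1CC[C@H](Oc2ccc(F)cc2)CC1`: 10200 nM
compound 2 `Cc1ccccc1NC(=O)N[C@H]1CC[C@H](Oc2ccc(F)cc2)CC1`: > 20000 nM, a limit of the assay
compound 3 `Cc1cccc(NC(=O)N[C@H]2CC[C@H](Oc3ccc(F)cc3)CC2)c1`: 14400 nM

In a functional assay on CRL2813 cells (Homo sapiens) for cytotoxicity, read by sulforhodamine B assay, with a stated time of 5 days (on this read-out higher numbers stand for weaker inhibition and lower numbers for stronger inhibition), compound 3 gives 14400 nM, the highest of the two numbers shown; the nearest is compound 1 , and the two differ by a 1.4-fold higher number from compound 1 to compound 3 (0.15 log units; within the scatter), which is within the scatter. The value of compound 2 is only a limit (the limit of > 20000 nM in this assay, at which 1 of the 3 values shown sits). Compound 4 `COc1cccc(NC(=O)N[C@H]2CC[C@H](Oc3ccc(F)cc3)CC2)c1` differs from compound 3 by methoxy in place of methyl on an aromatic carbon. Within the data shown here, no measured step swaps methyl for methoxy, so the expectation rests on the small steps seen so far: a 1.4-fold higher number from compound 1 to compound 3 (0.15 log units; within the scatter) and an at least 1.3-fold lower number from compound 2 to compound 3 (0.14 log units; that floor lies within the scatter), both within the scatter. The step from compound 3 to compound 4 is therefore expected to be a 1.0-fold higher number from compound 3 to compound 4 (0.02 log units; within the scatter), nothing beyond the scatter. Compound 4 is estimated at 15000 nM, between 7000 nM and 32000 nM.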

Compound 4, half-maximal inhibitory concentration: 14000 nM
For compound 4 the middle estimate is 1.1-fold (0.03 log units) above the measured one; measured number inside the range.
By their numbers in this assay, from the lowest: compounds 1, 4 and 3 (each within the scatter of the next). At a limit, above all of these: compound 2.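

In this assay, methoxy, which brings one hydrogen-bond acceptor to this aromatic carbon, cannot be told apart from methyl: a 1.0-fold lower number from compound 3 to compound 4 (0.01 log units; within the scatter). The 3-methoxyphenyl compound also stays within the scatter of the 4-iodophenyl compound, with a 1.4-fold higher number from compound 1 to compound 4 (0.14 log units; within the scatter). The step of an at least 1.4-fold lower number from compound 2 to compound 4 (0.15 log units; that floor lies within the scatter) is only a floor, set by a limit of the assay on compound 2: the limit of > 20000 nM in this assay, at which 1 of the 4 values shown sits.

Going by these compounds, whether an amine or a carboxylic acid at this position would give a step beyond the scatter remains open. So does whether any change to the shared core would.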